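The source may hold more compounds than are shown below. What is called first, only, known or untested is meant among the compounds shown, and "the series" means these compounds.

Of the compounds shown here, two from this series have been tested in a functional assay on UACC-62 cells (Homo sapiens) for antiproliferative activity, with a stated time of 48 h; on this read-out lower numbers stand for stronger inhibition of growth and higher numbers for weaker inhibition of growth. Compound 1, `Cc1cc(O)c(C2=NN(c3ccc(S(N)(=O)=O)cc3)C(c3ccccc3O)C2)cc1Cl`, gives 15500 nM. Compound 2, `Cc1cc(O)c(C2=NN(c3ccc(S(N)(=O)=O)cc3)C(c3ccccc3Cl)C2)cc1Cl`, gives 14400 nM. Among the compounds with values here, the one structural step that connects them, a 1.1-fold lower number from compound 1 to compound 2 (0.03 log units; within the scatter), shows that swapping these two groups on the aromatic ring leaves the read-out essentially unchanged. On the two numbers seen so far, compound 2 carries the lower one, but its gap to compound 1 is within the scatter, so neither compound can be called the stronger growth inhibitor.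

Compound 3, `Cc1cc(O)c(C2=NN(c3ccc(S(N)(=O)=O)cc3)C(/C=C/c3ccccc3)C2)cc1Cl`, has not yet been measured. It differs from compound 2 in one place: 2-phenylethenyl in place of 2-chlorophenyl on a saturated ring carbon. Within the data shown here, this replaces the whole aromatic group on the saturated ring carbon with a chain that carries its own phenyl group, a larger alteration than the single swap between compound 1 and compound 2. Among the measured compounds shown here, the only measured step, from compound 1 to compound 2, was within the scatter and concerns a different part of the molecule, so it offers little guidance on this change. For compound 3 in this assay the expected outcome is a 1.0-fold lower number from compound 2 to compound 3 (0.01 log units; within the scatter), with a wide range of uncertainty. The estimated value for compound 3 is 14000 nM, between 5000 nM and 40000 nM.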

Compound 3, concentration for total growth inhibition: 11400 nM
Compound 3: middle estimate off by 1.2-fold (0.09 log units), on the high side; measured number inside the range.
By their numbers in this assay, from the lowest: compounds 3, 2 and 1 (each within the scatter of the next).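

Until now, only the group on the aromatic ring at the saturated ring carbon had been exchanged; here that whole aromatic group gives way to 2-phenylethenyl, which brings a double bond outside aromatic rings. In this assay, this change gives a 1.3-fold lower number from compound 2 to compound 3 (0.10 log units; within the scatter) when it replaces 2-chlorophenyl and a 1.4-fold lower number from compound 1 to compound 3 (0.13 log units; within the scatter) when it replaces 2-hydroxyphenyl, so the read-out stays level in both comparisons, and none of the three compounds can be called the stronger growth inhibitor. This position therefore accepts a much larger change than the earlier pair tested without any shift that can be told from the scatter, although nothing available explains why the read-out holds steady.

On these data alone, all three groups at this position carry a phenyl ring, so it remains open whether a group without one, such as a simple methyl, a longer saturated carbon chain, an amine or a carboxylic acid, would give a similar number. As far as these compounds go, it is also open whether the double bond matters, which 2-phenylethyl, the same group with that bond saturated, could help to show.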